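This account rests on a few compounds, and the source may have more. Where it says the series, first, only, none or still open, it means among the compounds named here.

Measured so far:
compound 1 `O=C1O[C@@H](CN2CCC(c3ccc(F)cc3)CC2)CN1c1ccc(-n2cc(-c3ccccn3)cn2)c(F)c1` — 5.78
compound 2 `CC(=O)OC[C@H]1CN(c2ccc(-n3cc(-c4ccccn4)cn3)c(F)c2)C(=O)O1` — 2.09

In a physicochemical assay for lipophilicity, read by HPLC, measured as octanol-water partition (a higher number here means a more lipophilic compound, a lower number a more polar compound), compound 1 gives 5.78 and compound 2 gives 2.09. Compound 2 therefore stands lowest of the two numbers recorded; compound 1 is the nearer and only neighbour, and the gap between them lies beyond the scatter. The two differ in more than one place, so no single-point step between measured compounds is available, and nothing can be said of how the two structures account for the gap.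

The next compound, compound 3 `COC(=O)NC[C@H]1CN(c2ccc(-n3cc(-c4ccccn4)cn3)c(F)c2)C(=O)O1`, has not yet been measured in this assay. It differs from compound 2 in one place: (methoxycarbonyl)amino in place of acetoxy on a saturated chain carbon bound to a saturated ring carbon The group that leaves has no hydrogen-bond donor; the group that enters brings one, with the same count of acceptors and one more heavy atom.

On that basis the step from compound 2 to compound 3 is expected to be small and downward in this assay, with a real chance of falling within the scatter: a number 0.39 log units lower from compound 2 to compound 3 (beyond the scatter). Compound 3 is estimated at 1.7, within 1.2 to 2.2.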

Compound 3, partition coefficient: 2.03
Compound 3: middle estimate off by 0.33 log units, on the low side; the measured number falls inside the stated range.
By their numbers in this assay, from the lowest: compounds 3 and 2 (each within the scatter of the next); then compound 1.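

In this assay, for the compounds shown here, the first single-point step reads a number 0.06 log units lower from compound 2 to compound 3 (within the scatter), so on a saturated chain carbon bound to a saturated ring carbon this read-out does not separate (methoxycarbonyl)amino from acetoxy. That holds even though the entering group brings a hydrogen-bond donor and one more heavy atom, so for this one pair neither count is matched by a step beyond the scatter, and a single pair sets no rule for other groups at this position. No measurement shown here bears on the reason for this result.

Compound 1 gives 5.78 but differs from compound 2 and from compound 3 in more than one place, so its number cannot be tied to any single group and the steps to it cannot be read. Still open, from the compounds shown here alone, is whether an amine, a carboxylic acid or a longer chain on the same saturated chain carbon would stay within the scatter of these two groups in this assay, or whether the level seen so far belongs only to this pair of groups on the shared core.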